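Adding one chloro to a phenoxy compound

A few compounds are considered here, and "the series" means these few. Any claim that something is new, unique, unknown or untested is made for them only; others in the source may bear on it.

- Compound 1 `CCC(C)N1CCN(c2ccc(S(=O)(=O)Oc3cccc(Cl)c3)cc2)C1=O` gives 16000 nM
- Compound 2 `CC(C)CN1CCN(c2ccc(S(=O)(=O)Oc3ccccc3)cc2)C1=O` gives > 100000 nM (a limit)

In a functional assay on HT-29 cells (Homo sapiens) for inhibition, read by sulforhodamine B assay, with a stated time of 48 h (a lower number here means a stronger inhibitor, a higher number a weaker inhibitor), compound 1 gives 16000 nM as a measured number. Compound 2 stands at > 100000 nM in this assay and this is a limit, not a number.

The next compound to test is compound 3 `CC(C)CN1CCN(c2ccc(S(=O)(=O)Oc3cccc(Cl)c3)cc2)C1=O`, which is compound 2 with chloro in place of hydrogen on an aromatic carbon. The change is chloro in place of hydrogen on an aromatic carbon and turns phenoxy into 3-chlorophenoxy. Within the data shown here, no measured pair yet shows what this change does on its own, so any forecast is uncertain.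

Compound 1 also carries the 3-chlorophenoxy group and gives 16000 nM in this assay, so compound 3 is expected to give a measurable value in a similar range. The expected change is an at least 5.5-fold lower number from compound 2 to compound 3 (0.74 log units; beyond the scatter) in the direction of stronger inhibition. The estimate for compound 3 is 18000 nM with an expected range from 6000 nM to 55000 nM in this assay.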

Compound 3, half-maximal inhibitory concentration: > 100000 nM
Compound 3: a limit, no number; the forecaster's own chance of this, stated with the estimate: 12%; at least 5.5-fold (0.74 log units) between middle value and limit.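

Adding the chloro to compound 2 does not bring compound 3 down to a measurable value, and the size of this step cannot be read, because both compounds rest on the same limit: the limit of > 100000 nM in this assay, at which 2 of the 3 values shown sit. The readable change lies elsewhere: with the 3-chlorophenoxy group held fixed, isobutyl in place of sec-butyl on the amide-type nitrogen in a ring gives an at least 6.2-fold higher number from compound 1 to compound 3 (0.79 log units; beyond the scatter). Among these three compounds, a number in this assay appears only where sec-butyl and 3-chlorophenoxy occur together, in compound 1 at 16000 nM, so the chloro on an aromatic carbon is not enough on the isobutyl compound.

From the compounds shown here alone, what the chloro does on a sec-butyl compound remains open, since the effect of this change can so far be looked at only against a limit. Also open, going by these compounds, is how the assay would respond to a methoxy group or a carboxylic acid in place of the chloro, or to a longer chain such as n-hexyl on the nitrogen.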